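A few compounds are considered here, and "the series" means these few. Any claim that something is new, unique, unknown or untested is made for them only; others in the source may bear on it.

Measured so far in an assay on cells for inhibition of histone deacetylase 4 (Homo sapiens), read by fluorescence, with a stated time of 30 min; a lower number here means a stronger inhibitor, a higher number a weaker inhibitor:
compound 1 `O=C1NC(=O)/C(=C\c2ccc(OCC(=O)N3N=C(c4ccc(F)cc4)CC3c3ccccc3Cl)cc2)S1`: 1100 nM
compound 2 `Cc1ccc(C2CC(c3ccc(F)cc3)=NN2C(=O)COc2ccc(/C=C3/SC(=O)NC3=O)cc2)cc1`: 1800 nM

Of these two numbers compound 2 holds the higher one. Its nearest neighbour is compound 1, and the step of a 1.6-fold higher number from compound 1 to compound 2 (0.21 log units; within the scatter) lies within the usual scatter, so the two compounds are not separated by this assay.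

Compound 3 `O=C1NC(=O)/C(=C\c2ccc(OCC(=O)N3N=C(c4ccc(F)cc4)CC3c3ccc(Cl)c(Cl)c3)cc2)S1` is not yet measured. It differs from compound 2 at a single place: 3,4-dichlorophenyl in place of 4-methylphenyl on a saturated ring carbon. Among the compounds with values here, the only measured step that touches this same saturated ring carbon is the exchange of 2-chlorophenyl for 4-methylphenyl from compound 1 to compound 2, and that step stayed within the scatter. Within the data shown here, no measured compound carries a 3,4-dichlorophenyl group, so there is nothing in the data that points to a change beyond the scatter in this assay in either direction.

Compound 3 is therefore expected to give about 1300 nM in this assay, with a range of 500 nM to 3500 nM, which means an expected step of a 1.4-fold lower number from compound 2 to compound 3 (0.14 log units; within the scatter) that stays within the scatter.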

Compound 3, half-maximal inhibitory concentration: 800 nM
Estimate against measurement, compound 3: 1.6-fold (0.21 log units) above; the measured number falls inside the stated range.
By their numbers in this assay, from the lowest: compounds 3, 1 and 2 (each within the scatter of the next, the first and the last beyond it).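

In this assay, this saturated ring carbon shows its first change beyond the scatter: 3,4-dichlorophenyl in place of 4-methylphenyl gives a 2.3-fold lower number from compound 2 to compound 3 (0.35 log units; beyond the scatter), a modest step. Set against the 2-chlorophenyl group, the same entering group gives a 1.4-fold lower number from compound 1 to compound 3 (0.14 log units; within the scatter), so the assay does not separate these two compounds, and the groups at this carbon differ measurably only in the pair with the 4-methylphenyl group. Nothing available gives a reason for this modest step.

From the compounds shown here alone, all three compounds carry a phenyl ring on this carbon, so what an amine or a carboxylic acid on that ring, or a plain alkyl chain in its place, would do remains open. Also open, going by these compounds, is whether both chlorine atoms of the 3,4-dichlorophenyl group are needed for the step.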